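The source may hold more compounds than are shown below. What is called first, only, known or untested is meant among the compounds shown, and "the series" means these compounds.

Measured in a functional assay on DLD-1 cells (Homo sapiens) for antiproliferative activity, read by sulforhodamine B assay, with a stated time of 48 h; on this read-out higher numbers stand for weaker inhibition and lower numbers for stronger inhibition:
- compound 1 `COc1ccc(-c2oc3c(OC)c(OC)cc(OCCCC(=O)NCc4ccccn4)c3c(=O)c2O)cc1`: > 40000 nM (a limit)
- compound 2 `COc1ccc(-c2oc3c(OC)c(OC)cc(OCCCCC(=O)NCc4ccccn4)c3c(=O)c2O)cc1`: > 40000 nM (a limit)
- compound 3 `COc1ccc(-c2oc3c(OC)c(OC)cc(OCCCCCC(=O)N4CCN(C)CC4)c3c(=O)c2O)cc1`: 13700 nM

Compound 2 stands at the limit of > 40000 nM in this assay, at which 2 of the 3 values shown sit, so it has a limit and no number.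

Compound 4 `COc1ccc(-c2oc3c(OC)c(OC)cc(OCCCCCC(=O)NCc4ccccn4)c3c(=O)c2O)cc1` differs from compound 2 as follows: (((pyridin-2-yl)methyl)carbamoyl)methyl in place of ((pyridin-2-yl)methyl)carbamoyl on a saturated chain carbon, four bonds along the chain from an oxygen on an aromatic ring. On these data alone, the same kind of change gave a step that the two limits leave unreadable from compound 1 to compound 2, so its size is unknown. The other two steps, an at least 2.9-fold lower number from compound 1 to compound 3 (0.46 log units; beyond the scatter) and an at least 2.9-fold lower number from compound 2 to compound 3 (0.46 log units; beyond the scatter), also replace the pyridinylmethyl amide with the (4-methylpiperazin-1-yl)carbonyl group, so they are only a loose guide. In this assay, a small fall or none beyond the scatter is expected. The expected size is an at least 1.2-fold lower number from compound 2 to compound 4 (0.09 log units; that floor lies within the scatter). The estimate for compound 4 is 32000 nM, with an expected range of 14000 nM to 60000 nM.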

Compound 4, half-maximal inhibitory concentration: > 40000 nM
Compound 4 gave a limit, no number; the forecaster's own chance of this, stated with the estimate: 55%; middle value at least 1.2-fold (0.09 log units) from the limit.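

In this assay compound 4 gives > 40000 nM, which is a limit. The steps to it from compound 1 and compound 2 cannot be read, so no effect of chain length on the pyridinylmethyl amides can be stated. Among the compounds shown here, with the chain held constant, ((pyridin-2-yl)methyl)amino in place of 4-methylpiperazin-1-yl on a carbonyl carbon gives an at least 2.9-fold higher number from compound 3 to compound 4 (0.46 log units; beyond the scatter); this isolates the amide end, whereas the earlier steps to compound 3 changed the chain as well.

Still open, on these data alone, is whether the 4-methylpiperazin-1-yl amide keeps its activity on shorter chains. Also open, as far as these compounds go, is whether a morpholine amide, a terminal carboxylic acid or a longer chain would give a measurable value.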